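Trading carboxy for hydroxymethyl on the side chain of compound 1

A few compounds are considered here, and "the series" means these few. Any claim that something is new, unique, unknown or untested is made for them only; others in the source may bear on it.

Measured compounds:
compound 1 `Cc1nc(O)c2cc(-c3ccc(Cl)c(OCC(=O)O)c3)c(C(C)C)cc2n1`: > 1000 nM
compound 2 `COc1cc(Cl)cc(-c2cc3c(O)nc(C)nc3cc2C(C)C)c1`: 100 nM

In a functional assay for inhibition of transient receptor potential cation channel subfamily V member 1 (Homo sapiens), read by fluorescence and calcium flux (on this read-out lower numbers stand for stronger inhibition and higher numbers for weaker inhibition), compound 1 reaches only a limit of the assay, > 1000 nM, which is not a number. Compound 2 gives 100 nM in this assay. Compound 1 thus sits at the weak end of the numbers shown, as the limit of > 1000 nM in this assay, at which 1 of the 2 values shown sits, records. The unmeasured compound 3 `Cc1nc(O)c2cc(-c3ccc(Cl)c(OCCO)c3)c(C(C)C)cc2n1` differs from compound 1 by hydroxymethyl in place of carboxy on a saturated chain carbon bound to an oxygen on an aromatic ring. Among the compounds with values here, no measured pair shows this change, so its size is open; a step of an at least 3.3-fold lower number from compound 1 to compound 3 (0.52 log units; beyond the scatter) toward stronger inhibition is expected. Compound 3 is estimated at 300 nM, likely between 60 nM and 2000 nM.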

Compound 3, half-maximal inhibitory concentration: 557 nM
Compound 3: middle estimate off by 1.9-fold (0.27 log units), on the low side; low and high end bracket the measured number.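

With hydroxymethyl in place of carboxy on this saturated chain carbon bound to an oxygen on an aromatic ring, this assay shows an at least 1.7-fold lower number from compound 1 to compound 3 (0.25 log units; that floor lies within the scatter). Compound 3 thus gives a number, so a measurable value at this position does not depend on carboxy. The true size of the step cannot be fixed because compound 1 is recorded only as a limit: the limit of > 1000 nM in this assay, at which 1 of the 3 values shown sits.

On these data alone, whether an amine, an amide or a longer chain ending in hydroxyl at this place would give a lower number stays open.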